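This account rests on a few compounds, and the source may have more. Where it says the series, first, only, none or still open, it means among the compounds named here.

Of the compounds shown here, two sharing one core have been tested so far. Compound 1 `CCCCCc1c(C(C)C)nc(C(C)C)c(CO)c1-c1ccc(OC)cc1` gives 37% in an assay on CHO cells for inhibition of Glucagon receptor (Homo sapiens), tested at 20 uM (a lower number here means less inhibition, a higher number more inhibition at the concentration tested (going by the name of the read-out)), the higher of the two numbers. Compound 2 `CCCCCc1c(C(C)C)nc(C(C)C)c(CO)c1-c1cccc2ccccc12` gives 6%, well beyond the scatter below compound 1. The next compound, compound 3 `CCCCCc1c(C(C)C)nc(C(C)C)c(CO)c1-c1cccc(C)c1`, differs from compound 1 in one place: 3-methylphenyl in place of 4-methoxyphenyl on an aromatic carbon. Among the compounds with values here, no measured pair shows this change, so the size of its step is unknown. Compound 3 is estimated at 30%, within a range from 10% to 50%. The expected step of a number 7 percentage points lower from compound 1 to compound 3 (within the scatter) is small, lying within the scatter.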

Compound 3, a percentage reported as inhibition, at one concentration (the size of the read-out at that concentration, not a potency): 46%
Compound 3: the middle estimate sits 16 percentage points below what was measured, within the range that was stated.
By their numbers in this assay, from the lowest: compound 2; then compounds 1 and 3 (each within the scatter of the next).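

In this assay, putting 3-methylphenyl in place of 4-methoxyphenyl on this carbon opposite the ring nitrogen gives a number 9 percentage points higher from compound 1 to compound 3 (within the scatter). The two compounds cannot be told apart, so the hydrogen-bond acceptor counted in 4-methoxyphenyl is not required for this level of inhibition. No measurement here offers an explanation for this result. Group identity and ring placement change together in this swap, so their separate contributions remain open. Also open, as far as these compounds go, is whether a phenyl ring carrying an amine or a carboxylic acid would keep this level.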